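The source may report more compounds than this note shows. Statements on the series, on what has been measured and on what is new or still open speak of the compounds shown alone.

Working notes on the series. In a functional assay for inhibition, with Rattus norvegicus as the target (a higher number here means a weaker inhibitor, a lower number a stronger inhibitor), compound 1 `C[C@@H](/N=c1\c(O)c(O)\c1=N/c1ccc(C#N)cc1)C1CCCCC1` gives 2600 nM and compound 2 `COc1cc(C#N)ccc1/N=c1\c(O)c(O)\c1=N/[C@H](C)C(C)(C)C` gives 290 nM. Compound 2 therefore holds the lower of the two numbers and is the stronger inhibitor of this pair, with a gap beyond the usual scatter. The two compounds differ in more than one place, so their values do not isolate any single structural change.

Compound 3 `C[C@@H](/N=c1\c(O)c(O)\c1=N/c1ccc(C#N)cc1C(=O)c1ccccc1)C(C)(C)C` differs from compound 2 in one place: benzoyl in place of methoxy on an aromatic carbon, ortho to a large group and meta to a cyano group (benzoyl in place of methoxy on an aromatic carbon). Going by the values given here, no measured compound carries a benzoyl group, and no measured pair shows what replacing methoxy does, so the expectation rests on little and the range is kept wide. The estimated change is a 2.1-fold higher number from compound 2 to compound 3 (0.32 log units; beyond the scatter), a small weakening expected in this assay, and one that may not clear the scatter. For compound 3 the expected value is 600 nM, with an estimated range of 120 nM to 3000 nM.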

Compound 3, half-maximal inhibitory concentration: 4780 nM
Estimate against measurement, compound 3: 8.0-fold (0.90 log units) below; measured number outside the range, above it.
By their numbers in this assay, from the lowest: compound 2; then compounds 1 and 3 (each within the scatter of the next).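

The aromatic carbon ortho to a large group and meta to a cyano group is a sensitive place in this assay: benzoyl in place of methoxy gives a 16-fold higher number from compound 2 to compound 3 (1.22 log units; beyond the scatter) as a large step. The earlier pair differed in more than one place and could not show this, whereas this step isolates a single change, in which methoxy with 2 heavy atoms gives way to benzoyl with 8 heavy atoms and one six-membered aromatic ring of carbon only. Nothing available on these compounds speaks to the reason for the step.

The compounds shown leave open which part of benzoyl goes with the weaker number, since a phenyl, an acetyl or a plain hydrogen on this aromatic carbon would each separate the carbonyl from the added ring. They also leave open whether a step of this size holds when a cyclohexyl group, as in compound 1, replaces the tert-butyl group of compound 2 and compound 3.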